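Thiourea series: a cyanophenyl group in place of methoxyphenyl

The source may report more compounds than this note shows. Statements on the series, on what has been measured and on what is new or still open speak of the compounds shown alone.

Of the compounds shown here, three have been measured in a functional assay on T98G cells (Homo sapiens) for inhibition, read by MTT assay, with a stated time of 72 h; on this read-out higher numbers stand for weaker inhibition and lower numbers for stronger inhibition. Compound 1 `COc1cccc(NC(=S)NC2CC(C)(C)Oc3ccc(Br)cc32)c1` gives 87000 nM in this assay, the highest of the three numbers. Compound 2 `O=[N+]([O-])c1ccc(NC(=S)NC2CCOc3ccc(Cl)cc32)cc1` gives 12000 nM, a lower number than compound 1 by a margin beyond the scatter. Compound 3 `CC1(C)CC(NC(=S)Nc2cccc([N+](=O)[O-])c2)c2cc(Cl)ccc2O1` gives 4000 nM, the lowest number of the three and again beyond the scatter from compound 1. Both of the lower numbers belong to compounds that carry a nitrophenyl group on the thiourea nitrogen, while compound 1 carries a 3-methoxyphenyl group there.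

Compound 4 `CC1(C)CC(NC(=S)Nc2ccc(C#N)cc2)c2cc(Br)ccc2O1` is not yet measured. It differs from compound 1 in one place: 4-cyanophenyl in place of 3-methoxyphenyl on an amide-type nitrogen. Going by the values given here, no single-change step between measured compounds is at hand, so the size of this step is an expectation only. Given that compound 1 gives 87000 nM and that the two measured compounds with a polar aryl substituent give lower numbers, the step of a 4.4-fold lower number from compound 1 to compound 4 (0.64 log units; beyond the scatter) is expected to run toward a lower number, beyond the scatter. Compound 4 is expected to give about 20000 nM in this assay, within a range from 5000 nM to 60000 nM.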

Compound 4, half-maximal inhibitory concentration: 24000 nM
Estimate against measurement, compound 4: 1.2-fold (0.08 log units) below; the measured number falls inside the stated range.
By their numbers in this assay, from the lowest: compound 3; then compounds 2 and 4 (each within the scatter of the next); then compound 1.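

In this assay, going by these compounds alone, the aryl group on the amide-type nitrogen is the only difference within this pair, and 4-cyanophenyl in place of 3-methoxyphenyl gives a 3.6-fold lower number from compound 1 to compound 4 (0.56 log units; beyond the scatter) on the shared core. This first single-change step in the series shows that the number responds to this position alone, though the step is modest. The two groups match in heavy atoms and hydrogen-bond acceptors, and nothing measured here accounts for the step.

The names 3-methoxyphenyl and 4-cyanophenyl differ in both the substituent and its ring number, and the compounds shown do not separate these two changes. Also open, from the compounds shown here alone, is how an amine or a carboxylic acid on the phenyl ring would read at this position.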